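The source may report more compounds than this note shows. Statements on the series, on what has been measured and on what is new or still open speak of the compounds shown alone.

In an ADME assay on NHDF cells (Homo sapiens) for cytotoxicity, read by MTT assay, with a stated time of 72 h (a higher number here means a weaker inhibitor, a lower number a stronger inhibitor), compound 1 `COc1cccc(/C=C2\CCC/C(=C\c3ccc(Cl)cc3)C2=O)c1OC` gives 18600 nM and compound 3 `COc1cccc(/C=C2\CCC/C(=C\c3ccc(Br)cc3)C2=O)c1OC` gives 21400 nM with no separation between them, since a 1.2-fold higher number from compound 1 to compound 3 (0.06 log units; within the scatter) stays within the scatter. Compound 2 `COc1cccc(/C=C2\CCC/C(=C\c3ccccc3Br)C2=O)c1OC` gives > 50000 nM as its reading, which is a limit of the assay. Compound 4 `COc1ccccc1/C=C1\CCC/C(=C\c2cccc(OC)c2OC)C1=O` differs from compound 3 by 2-methoxyphenyl in place of 4-bromophenyl on a double-bonded chain carbon bound to a double-bonded ring carbon on a double-bonded chain carbon bound to a double-bonded ring carbon. Among the compounds with values here, two measured steps bear on this, both through the 2-bromophenyl of compound 2: an at least 2.6-fold higher number from compound 1 to compound 2 (0.42 log units; beyond the scatter) and an at least 2.3-fold lower number from compound 2 to compound 3 (0.36 log units; beyond the scatter) are both modest at the least and leave that compound at the higher number. Within the data shown here, no measured compound tests methoxy against bromo on this ring, so only a modest rise in this assay is expected. The expected change is a 2.1-fold higher number from compound 3 to compound 4 (0.32 log units; beyond the scatter) in size. Compound 4 is estimated at 45000 nM within an expected range of 18000 nM to 100000 nM for this measurement.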

Compound 4, half-maximal inhibitory concentration: 31300 nM
Beside the measured number, compound 4's estimate is 1.4-fold (0.16 log units) above it; low and high end bracket the measured number.
By their numbers in this assay, from the lowest: compounds 1, 3 and 4 (each within the scatter of the next). At a limit, above all of these: compound 2.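

In this assay the 2-methoxyphenyl in place of 4-bromophenyl on this double-bonded chain carbon brings no separation (a 1.5-fold higher number from compound 3 to compound 4 (0.17 log units; within the scatter)). The same holds against 4-chlorophenyl (a 1.7-fold higher number from compound 1 to compound 4 (0.23 log units; within the scatter)), so compound 4 stands with compound 1 and compound 3. Methoxy in place of bromo on an aromatic carbon yields only a floor (an at least 1.5-fold lower number from compound 2 to compound 4 (0.20 log units; that floor lies within the scatter)), and no separation can be read, because that step rests on a limit: the limit of > 50000 nM in this assay, at which 1 of the 4 values shown sits.

Open, going by these compounds, is whether an amine or a carboxylic acid in this place would move the number beyond the scatter. Also open, on these data alone, is how far compound 2 truly lies from the others.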